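The source may report more compounds than this note shows. Statements on the series, on what has been measured and on what is new or still open speak of the compounds shown alone.

In an ADME assay on the whole organism for pharmacokinetics, with Mus musculus as the target, at a dose of 10 mg/kg by the oral route (a higher number here means more compound in the circulation at the dose given, a lower number less compound in the circulation), compound 1 (`CC/C(=C(/c1ccc(/C=C/C(=O)O)cc1)c1cccc2[nH]ncc12)c1ccccc1`) gives 2800 ng.h/mL and compound 2 (`CC/C(=C(/c1ccc(/C=C/C(=O)O)cc1)c1ccc2[nH]ncc2c1)c1ccccc1C#N`) gives 200 ng.h/mL on the same scale. Compound 2 therefore holds the lower of the two numbers, by a gap beyond the usual scatter. These two compounds differ in more than one place, so their gap cannot be tied to a single group. Compound 3 (`CC/C(=C(/c1ccc(/C=C/C(=O)O)cc1)c1ccc2[nH]ncc2c1)c1cscc1C`) carries 4-methylthiophen-3-yl in place of 2-cyanophenyl on a double-bonded chain carbon bound to a double-bonded chain carbon and a saturated chain carbon and otherwise matches compound 2. Among the compounds with values here, no measured pair isolates this swap, so any forecast is a judgement. Compound 1 also has no nitrile and stands at 2800 ng.h/mL in this measure, which points towards a rise. A rise is expected, estimated here as a 4.0-fold higher number from compound 2 to compound 3 (0.60 log units; beyond the scatter) and so larger than the usual scatter. For compound 3 the estimated value is 800 ng.h/mL with an expected range (200 ng.h/mL to 3000 ng.h/mL).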

Compound 3, area under the concentration-time curve: 3800 ng.h/mL
Compound 3: middle estimate off by 4.8-fold (0.68 log units), on the low side, and the stated range ends below it.
By their numbers in this assay, from the lowest: compound 2; then compounds 1 and 3 (each within the scatter of the next).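

Within the data shown here, this is the first pair to differ in only one place, so the group on the double-bonded chain carbon bound to a double-bonded chain carbon and a saturated chain carbon can now be judged on its own: in this assay, 4-methylthiophen-3-yl in place of 2-cyanophenyl gives a 19-fold higher number from compound 2 to compound 3 (1.28 log units; beyond the scatter). The amount in the circulation therefore depends strongly on the group at this place, at least for these two groups. The swap removes the nitrile and also replaces the six-membered carbon ring with a five-membered sulfur-containing ring carrying a methyl group, and no measurement shown here explains the rise.

As far as these compounds go, whether the step comes from losing the nitrile or from the change of ring remains open. A comparison with 2-methylphenyl at the same place would help separate these two changes.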